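Indole Nitrogen Substituent Change in a Platelet-Activating Factor Series

A few compounds are considered here, and "the series" means these few. Any claim that something is new, unique, unknown or untested is made for them only; others in the source may bear on it.

Of the compounds shown here, three built on a shared core have been measured in a functional assay (Oryctolagus cuniculus) for antagonist activity at platelet-activating factor receptor (Cavia porcellus); a lower number here means a stronger inhibitor, a higher number a weaker inhibitor. Compound 1 `O=C(c1ccn2c1CSC2c1cccnc1)c1c[nH]c2cccc(O)c12` gives 327 nM. Compound 2 `CN(C)C(=O)n1cc(C(=O)c2ccn3c2CSC3c2cccnc2)c2ccc(Cl)cc21` gives 89 nM. Compound 3 `CCNC(=O)n1cc(C(=O)c2ccn3c2CSC3c2cccnc2)c2ccc(-c3ccc(F)cc3)cc21` gives 19 nM, the lowest of the three numbers: compound 2 stands at a higher number beyond the scatter, and compound 1 stands further away still, also beyond the scatter. None of these compounds differs from another in a single place, so no step between measured compounds can be traced.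

Compound 4 `CN(C)C(=O)Cn1cc(C(=O)c2ccn3c2CSC3c2cccnc2)c2ccc(-c3ccc(F)cc3)cc21` has not yet been measured. It differs from compound 3 in one place: (dimethylcarbamoyl)methyl in place of ethylcarbamoyl on an aromatic nitrogen. The closest point of comparison is compound 2, which also carries a dimethylcarbamoyl group on that nitrogen, but compound 2 differs from compound 4 in a second place as well, so what its value shows cannot be separated into parts.

Among the compounds with values here, with no traced step to lean on, the change is expected to cost little or nothing beyond the scatter, with the step of a 1.6-fold higher number from compound 3 to compound 4 (0.20 log units; within the scatter) estimated as small and toward a weaker inhibitor. Compound 4 is therefore estimated at 30 nM, within a range from 8 nM to 110 nM.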

Compound 4, inhibition constant: 0.7 nM
The estimate for compound 4 lay 43-fold (1.63 log units) above the measured number; the whole stated range lies above it.
By their numbers in this assay, from the lowest: compound 4; then compound 3; then compound 2; then compound 1.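

In this assay, the group on the aromatic nitrogen proves to matter a great deal: with (dimethylcarbamoyl)methyl in place of ethylcarbamoyl and the rest of the structure unchanged, the result is a 27-fold lower number from compound 3 to compound 4 (1.43 log units; beyond the scatter). The earlier compounds shown here could not show this, since none of them differed from another in a single place, and this step isolates the nitrogen substituent from the other differences. The swap still alters more than one feature of the substituent, removing the amide hydrogen of ethylcarbamoyl and holding the carbamoyl group on a methyl link rather than directly on the nitrogen, and nothing available here bears on why the step is so large.

The compounds shown do not separate these two features: an (ethylcarbamoyl)methyl group would keep the amide hydrogen on the methyl link, and a dimethylcarbamoyl group set directly on this nitrogen of the core of compound 3 would remove that hydrogen without the link. Also open, going by these compounds, is how this position responds to a longer chain between the nitrogen and the amide, or to a carboxylic acid or an amine in place of the amide at the end of the link.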